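A few compounds are considered here, and "the series" means these few. Any claim that something is new, unique, unknown or untested is made for them only; others in the source may bear on it.

Compound 1 `O=c1oc2ccccc2c2nc3c(ccc4cc[nH]c43)c(-c3ccc(Cl)cc3)c12` is one of three close relatives tested in a functional assay on B16-F10 cells (Mus musculus) for cytotoxicity (on this read-out higher numbers stand for weaker inhibition and lower numbers for stronger inhibition), where compound 1 gives 70700 nM. Compound 2 `O=c1oc2ccccc2c2nc3c(ccc4cc[nH]c43)c(-c3cccc4ccccc34)c12` gives 70700 nM, and compound 3 `Cc1ccc(-c2c3ccc4cc[nH]c4c3nc3c2c(=O)oc2ccccc23)cc1` gives 70700 nM, so compound 1 sits level with both. The change from compound 1 to compound 4 `O=c1oc2ccccc2c2nc3c(ccc4cc[nH]c43)c(-c3ccc([N+](=O)[O-])cc3)c12` is nitro in place of chloro on an aromatic carbon. Among the measured compounds shown here, no measured step puts a nitro group on the shared core, but the steps that swap the group on the same aromatic carbon all stayed flat: no change at the digits printed from compound 1 to compound 2 (within the scatter), no change at the digits printed from compound 1 to compound 3 (within the scatter) and no change at the digits printed from compound 2 to compound 3 (within the scatter). Nothing here suggests that another exchange at that position would move the read-out, so compound 4 is expected to give 70700 nM, in the range 35000 nM to 141000 nM, a step of no change at the digits printed from compound 1 to compound 4 (within the scatter).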

Compound 4, half-maximal inhibitory concentration: 70700 nM
The estimate for compound 4 equals the measured number at the digits printed, and the stated range covers the measured number.
By their numbers in this assay, from the lowest: compounds 1, 2, 3 and 4 (each within the scatter of the next).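

The earlier exchanges at this aromatic carbon involved only chloro, methyl and naphthalen-1-yl, none with a hydrogen-bond acceptor. The nitro group brings in nitrogen, oxygen and two hydrogen-bond acceptors, yet in this assay the read-out stays flat with this change (no change at the digits printed from compound 1 to compound 4 (within the scatter)), and the same holds against the other two compounds (no change at the digits printed from compound 3 to compound 4 (within the scatter); no change at the digits printed from compound 2 to compound 4 (within the scatter)). Across these four compounds, then, the group at this place has shown no effect on the number.

On these data alone, whether an amine or a carboxylic acid here, or a change elsewhere on the shared core, would move the read-out remains open. Nothing available accounts for this flat result.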